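Carboxy in Place of Methoxy on the Core of Compound 1

A few compounds are considered here, and "the series" means these few. Any claim that something is new, unique, unknown or untested is made for them only; others in the source may bear on it.

Three compounds were measured in a functional assay on Lewis lung carcinoma cells for cytotoxicity against Lewis lung carcinoma cell line (Mus musculus), read by MTT assay, with a stated time of 72 h; a lower number here means a stronger inhibitor, a higher number a weaker inhibitor:

compound 1, `COc1ccccc1/C=C1\COC/C(=C\c2ccccc2F)C1=O`, gives 15400 nM
compound 2, `COc1ccc(/C=C2\COC/C(=C\c3ccccc3F)C2=O)cc1O`, gives 9600 nM
compound 3, `COc1ccc(OC)c(/C=C2\COC/C(=C\c3ccccc3F)C2=O)c1`, gives 15100 nM

Compound 1 stands at the highest of the three numbers, but its nearest neighbour is compound 3, and the two lie within the scatter of each other; the gap to compound 2 is also within the scatter. Among the measured compounds shown here, the only single-place step among them, a 1.0-fold lower number from compound 1 to compound 3 (0.01 log units; within the scatter), adds a methoxy and moves nothing.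

Compound 4, `O=C1/C(=C/c2ccccc2F)COC/C1=C\c1ccccc1C(=O)O`, differs from compound 1 as follows: carboxy in place of methoxy on an aromatic carbon. For the measured compounds named here, no measured step exchanges a methoxy for a carboxy, so the record offers only the observation that a methoxy added to compound 1 left its number where it was. Without a bearing step, the expectation for compound 4 rests on compound 1 alone, and the estimated step of a 1.2-fold higher number from compound 1 to compound 4 (0.07 log units; within the scatter) is one that stays within the scatter. Compound 4 is therefore expected to give about 18000 nM, within a range from 7000 nM to 45000 nM.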

Compound 4, half-maximal inhibitory concentration: 17200 nM
The estimate for compound 4 lay 1.0-fold (0.02 log units) above the measured number; low and high end bracket the measured number.
By their numbers in this assay, from the lowest: compounds 2, 3, 1 and 4 (each within the scatter of the next).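

On the aromatic carbon that carries the methoxy of compound 1, ortho to a large group, the exchange for carboxy gives a 1.1-fold higher number from compound 1 to compound 4 (0.05 log units; within the scatter) in this assay. The earlier step showed only that a methoxy added to compound 1 left the number in place; this one changes the group already present, and even carboxy, which unlike methoxy counts a hydrogen-bond donor, leaves the number within the scatter. Nothing measured here says why this change leaves the number in place.

The compounds shown leave open whether an amine, a hydroxy or a longer chain on this same carbon would also stay within the scatter of compound 1. They also leave open whether any group at this position can move the number beyond the scatter at all.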